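A few compounds are considered here, and "the series" means these few. Any claim that something is new, unique, unknown or untested is made for them only; others in the source may bear on it.

Measured compounds in an assay on CHO-K1 cells for antagonist activity at adenosine receptor A1 (Homo sapiens), read by a beta-galactosidase reporter, with stated times of 15 min and 6 h; a lower number here means a stronger inhibitor, a higher number a weaker inhibitor:
Compound 1, `Nc1nc(-c2ccco2)nc2sc(CNC3CCCCC3)cc12`, gives 2480 nM.
Compound 2, `Nc1nc(-c2ccco2)nc2sc(CN3CCC(O)CC3)cc12`, gives 4000 nM.

For the measured compounds named here, compound 2 holds the upper of the two numbers in this assay, and its only neighbour, compound 1, is close: the step of a 1.6-fold higher number from compound 1 to compound 2 (0.21 log units; within the scatter) lies within the scatter of repeated measurements. Compound 3, `Nc1nc(-c2ccco2)nc2sc(CN3CC=CC3)cc12`, has not yet been measured in this assay. It differs from compound 2 in one place: a group of 5 heavy atoms (4 carbon, 1 nitrogen; one five-membered non-aromatic ring with 1 hetero atom) in place of a group of 7 heavy atoms (5 carbon, 1 nitrogen, 1 oxygen; one six-membered non-aromatic ring with 1 hetero atom), on a saturated chain carbon bound to an aromatic carbon. Going by the values given here, only one measured step bears on this change, and only loosely. Going from compound 1 to compound 2 also exchanged the group on the saturated chain carbon bound to an aromatic carbon, and that exchange moved the number by a 1.6-fold higher number from compound 1 to compound 2 (0.21 log units; within the scatter). Among the compounds with values here, with that as the sole guide, a small step is expected in this assay from compound 2 to compound 3, of a size no larger than the scatter and without a clear direction. Compound 3 is therefore estimated at 3200 nM in this assay, with a range from 1200 nM to 8500 nM, which corresponds to an expected step of a 1.3-fold lower number from compound 2 to compound 3 (0.10 log units; within the scatter).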

Compound 3, inhibition constant: 290 nM
For compound 3 the middle estimate is 11-fold (1.04 log units) above the measured one, and the stated range ends above it.
By their numbers in this assay, from the lowest: compound 3; then compounds 1 and 2 (each within the scatter of the next).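

In this assay, the exchange of cyclohexylamino for 4-hydroxypiperidin-1-yl had shown only a 1.6-fold higher number from compound 1 to compound 2 (0.21 log units; within the scatter), which gave no sign that the number at this position could shift much. The group of 5 heavy atoms, a five-membered non-aromatic ring with 1 double bond outside aromatic rings, now gives a 14-fold lower number from compound 2 to compound 3 (1.14 log units; beyond the scatter) and an 8.6-fold lower number from compound 1 to compound 3 (0.93 log units; beyond the scatter), so the group on the saturated chain carbon bound to an aromatic carbon can move the number well beyond the scatter. Compound 3 therefore stands apart from compound 1 and compound 2, whose two six-membered groups sit within the scatter of each other, but it differs from them in ring size, in the double bond and, against compound 2, in the loss of the hydroxyl group, all at once.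

No measurement shown here explains why this group gives the lower number. Which of these differences carries the step stays open, since the compounds shown do not tell how a pyrrolidin-1-yl group or a plain piperidin-1-yl group would read at this place.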